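Hydroxy Added to the Pyrrolidine Ring of Compound 3

The compounds below may be only part of what the source reports. "The series", "measured", "known", "first", "only" and "open" are said of these compounds alone.

Of the compounds shown here, three have so far been measured in a functional assay for antagonist activity at melanin-concentrating hormone receptor 1 (Homo sapiens); a lower number here means a stronger inhibitor, a higher number a weaker inhibitor. Compound 1 `N#Cc1cccc(-c2ccc(CN(CCN3CCCC3)C(=O)Nc3ccc(F)c(Cl)c3)cc2)c1` gives 287 nM. Compound 2 `N#Cc1cccc(-c2ccc(CN(CCCN3CCCC3)C(=O)Nc3cc(Cl)cc(Cl)c3)cc2)c1` gives 48 nM in this assay. Compound 3 `N#Cc1cccc(-c2ccc(CN(CC(=O)Nc3cc(Cl)cc(Cl)c3)C(=O)CN3CCCC3)cc2)c1` gives 35 nM in this assay, the lowest of the three numbers; the number of compound 2 lies within the usual scatter of it, whereas compound 1 stands clearly beyond the scatter with the highest number of the set.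

Compound 4 `N#Cc1cccc(-c2ccc(CN(CC(=O)Nc3cc(Cl)cc(Cl)c3)C(=O)CN3CC[C@@H](O)C3)cc2)c1` differs from compound 3 in a single place: hydroxy in place of hydrogen on a saturated ring carbon. Among the compounds with values here, no pair among the measured compounds shows this same change, so the measured numbers give no direct guide to how this assay answers it; everything else in compound 3 is kept unchanged. The expected step is a 1.3-fold higher number from compound 3 to compound 4 (0.11 log units; within the scatter), judged to fall within the scatter, with at most a slightly higher number. Compound 4 is accordingly estimated at 45 nM, within a range from 15 nM to 130 nM.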

Compound 4, inhibition constant: 61 nM
Compound 4: middle estimate off by 1.4-fold (0.13 log units), on the low side; measured number inside the range.
By their numbers in this assay, from the lowest: compounds 3, 2 and 4 (each within the scatter of the next); then compound 1.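

In this assay, within the data shown here, the hydroxy gives a 1.7-fold higher number from compound 3 to compound 4 (0.24 log units; within the scatter), the first comparison in this set between compounds that differ in one place. The step stays within the scatter, so this saturated ring carbon, two ring bonds from the ring nitrogen, accepts hydroxy in place of hydrogen, and with it one added hydrogen-bond donor and acceptor, without a difference the assay can separate from repeat measurements. Nothing available bears on why the assay answers this change as it does.

As far as these compounds go, whether the mirror-image hydroxy on the same carbon, or a methoxy, an amine or a carboxylic acid there, would be accepted equally remains open. Also open, from the compounds shown here alone, is whether the same hydroxy would give a comparable step on the pyrrolidine ring of compound 2.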